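The source may report more compounds than this note shows. Statements on the series, on what has been measured and on what is new or still open speak of the compounds shown alone.

Of the compounds shown here, three built around one shared core have been measured in a functional assay on A549 cells (Homo sapiens) for antiproliferative activity, read by sulforhodamine B assay, with a stated time of 3 days; on this read-out higher numbers stand for weaker inhibition of growth and lower numbers for stronger inhibition of growth. Compound 1 `COc1ccc(N2CCN(C)CC2)cc1Nc1ncc(F)c(Nc2ccc(F)cc2)n1` gives 1130 nM, the lowest number of the three. Compound 3 `COc1cc(NC(=O)c2cccc(Nc3ncc(F)c(Nc4ccc(F)cc4)n3)c2)cc(OC)c1` gives 13900 nM. Compound 2 `O=C(Nc1cccc(Nc2ncc(F)c(Nc3ccc(F)cc3)n2)c1)c1ccccc1` gives 37800 nM, the highest of the three numbers: compound 3 sits nearest with a number well beyond the scatter below it, and compound 1 lies furthest with a number far below it. Compound 2 is therefore the weakest inhibitor of growth among these three.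

Compound 4 `CN1CCC(C(=O)Nc2cccc(Nc3ncc(F)c(Nc4ccc(F)cc4)n3)c2)CC1` differs from compound 2 in one place: 1-methylpiperidin-4-yl in place of phenyl on a carbonyl carbon. Among the compounds with values here, no pair of measured compounds shows exactly this change, so its effect has to be estimated from the spread of the three numbers alone. The narrow shape of that spread, with compound 2 at the weak end, leaves more room to move down than up. The expected step in this assay from compound 2 to compound 4 is a 3.2-fold lower number from compound 2 to compound 4 (0.50 log units; beyond the scatter), a modest gain that may still fall close to the scatter. Compound 4 is therefore expected to give about 12000 nM, within a range of 3500 nM to 40000 nM.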

Compound 4, concentration for 50% growth inhibition: 1330 nM
The estimate for compound 4 lay 9.0-fold (0.96 log units) above the measured number; measured number below the stated range.
By their numbers in this assay, from the lowest: compounds 1 and 4 (each within the scatter of the next); then compound 3; then compound 2.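

In this assay, putting 1-methylpiperidin-4-yl in place of phenyl on a carbonyl carbon gives a 28-fold lower number from compound 2 to compound 4 (1.45 log units; beyond the scatter), a large step. This is the first one-place change among these compounds, and it shows that the group on this carbonyl carbon can strongly shift the read-out, though the change swaps an aromatic carbon ring for a non-aromatic ring with a nitrogen, so those two differences cannot be told apart. Nothing measured here explains the size of the step.

As far as these compounds go, whether the nitrogen matters remains open: cyclohexyl would keep a non-aromatic ring without nitrogen, while 4-pyridyl would keep an aromatic ring with one. From the compounds shown here alone, how an open-chain amine such as dimethylaminomethyl or a carboxylic acid would behave on this carbonyl carbon also remains unknown.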